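From compound 3 to compound 4 at the assay limit

The source may report more compounds than this note shows. Statements on the series, on what has been measured and on what is new or still open speak of the compounds shown alone.

In a functional assay on BGC-823 cells (Homo sapiens) for cytotoxicity, read by MTT assay (on this read-out lower numbers stand for stronger inhibition and higher numbers for weaker inhibition), compound 3 (`Cc1c(O)cc(CCCC(C)C)oc1=O`) gives > 200000 nM as its reading, and this is a limit, not a number. Compound 2 (`Cc1c(O)cc(CCCCC(C)C)oc1=O`) gives > 200000 nM as its reading, again a limit. Compound 1 (`COc1cc(CCCCC(C)(C)O)oc(=O)c1C`) gives > 200000 nM as its reading, also a limit. Compound 3 thus shares its place with the other two, and no order among the three can be read.

Compound 4 (`Cc1c(O)cc(CCCCC(C)(C)O)oc1=O`) is still unmeasured, and 2-hydroxy-2-methylpropyl in place of isopropyl on a saturated chain carbon, three bonds along the chain from an aromatic carbon sets it apart from compound 3. Compound 1 also carries the 2-hydroxy-2-methylpropyl group and reads > 200000 nM as a limit. Among the compounds with values here, the one measured step at this place is a step that the two limits leave unreadable from compound 2 to compound 3 and yields no size to carry over (because (the limit of > 200000 nM in this assay, at which 3 of the 3 values shown sit)).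

No step beyond the scatter is therefore expected in this assay and the most likely outcome is another limit reading. The expected change is a number no higher from compound 3 to compound 4 (the limit leaves the size open) in this estimate. For compound 4 the estimated value is 200000 nM with an expected range from 100000 nM to 400000 nM in this assay.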

Compound 4, half-maximal inhibitory concentration: > 200000 nM
Compound 4 was reported as a limit; the forecaster's own chance of this, stated with the estimate: 85%; the middle value lies on the limit itself.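

No step can be read between compound 4 and compound 1, compound 2 or compound 3, because all four readings sit at one limit and give no number: the limit of > 200000 nM in this assay, at which 4 of the 4 values shown sit.

The compounds shown leave open any order among these four and whether a change on the shared core can give a reading that is a number.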